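The compounds below may be only part of what the source reports. "The series", "measured", "known", "first", "only" and "open" are said of these compounds alone.

Compound 2 `O=C(/C=C/c1cc2ccccc2[nH]c1=O)c1ccc(O)cc1` stands lowest of the two numbers measured in a functional assay on EKVX cells (Homo sapiens) for cytotoxicity, read by sulforhodamine B assay, with a stated time of 24 h (on this read-out lower numbers stand for stronger inhibition of growth and higher numbers for weaker inhibition of growth), where compound 2 gives 27200 nM. Its nearest neighbour is compound 1 `COc1ccc(C(=O)/C=C/c2cc3ccccc3[nH]c2=O)cc1`, which in this assay gives 83800 nM. Among the measured compounds shown here, the step of a 3.1-fold lower number from compound 1 to compound 2 (0.49 log units; beyond the scatter) is the only measured step in this set: hydrogen in place of methyl on an oxygen on an aromatic ring.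

Compound 3 `O=C(/C=C/c1cc2ccccc2[nH]c1=O)c1ccc(Cl)cc1` differs from compound 2 by chloro in place of hydroxy on an aromatic carbon, on an aromatic carbon of a six-membered aromatic ring of carbon only. For the measured compounds named here, no measured step bears directly on this change. Going by the values given here, the single step available alters the oxygen substituent of that ring rather than exchanging the oxygen for a halogen, so the direction of the step in this assay cannot be read from compound 1 and compound 2. Because a 3.1-fold lower number from compound 1 to compound 2 (0.49 log units; beyond the scatter) was modest, a change of comparable size in either direction is expected here, with no firm lean. Compound 3 is therefore expected to give about 40000 nM in this assay, within 15000 nM to 120000 nM, which corresponds to an expected step of a 1.5-fold higher number from compound 2 to compound 3 (0.17 log units; within the scatter).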

Compound 3, concentration for total growth inhibition: > 100000 nM
Compound 3: only a limit was reported; the forecaster's own chance of this, stated with the estimate: 10%; middle value at least 2.5-fold (0.39 log units) from the limit.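

In this assay, exchanging the 4-hydroxyphenyl for the 4-chlorophenyl removes the oxygen from this position altogether, which the earlier step did not do, and it gives an at least 3.6-fold higher number from compound 2 to compound 3 (0.56 log units; beyond the scatter), so chloro here gives clearly weaker inhibition of growth than hydroxy. Compound 3 gives no number, only a limit: the limit of > 100000 nM in this assay, at which 1 of the 3 values shown sits. Chloro in place of methoxy gives an at least 1.1-fold higher number from compound 1 to compound 3 (0.07 log units; that floor lies within the scatter), but that floor lies within the scatter and sets no order between the two, so the firm finding is that hydroxy, with its steps to both methoxy and chloro beyond the scatter, gives the strongest inhibition of growth of the three groups at this position.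

On these data alone, how far the true value of compound 3 lies past its limit stays open, and with it the full size of both steps into that compound. Also open, as far as these compounds go, is whether an amine, a carboxylic acid or a hydroxymethyl group on the same aromatic carbon would match hydroxy, and whether fluoro or bromo would behave as chloro does.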